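A few compounds are considered here, and "the series" means these few. Any claim that something is new, unique, unknown or untested is made for them only; others in the source may bear on it.

Working notes on the series. Compound 1 `CC(C)(C)OC(=O)N1CCN(C(=O)COC2=CC(=O)c3c(O)cccc3C2=O)CC1` opens the set; in a functional assay on T47D cells (Homo sapiens) for antiproliferative activity (on this read-out higher numbers stand for weaker inhibition and lower numbers for stronger inhibition), compound 1 gives 800 nM. Compound 2 `O=C(O)CCCCCNC(=O)COC1=CC(=O)c2c(O)cccc2C1=O` ends its chain in a carboxylic acid; in this assay compound 2 gives "not determined" (no result reported), so it contributes no number. Compound 3 `CC(C)(C)OC(=O)NCCCCC(CNC(=O)COC1=CC(=O)c2c(O)cccc2C1=O)NC(=O)OC(C)(C)C` carries two (tert-butoxycarbonyl)amino groups on its chain; in this assay compound 3 gives 1400 nM. On the numbers in hand compound 3 stands highest of the two, with compound 1 as its nearest neighbour, and the gap between them lies within the scatter, so no order between the two is read.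

Compound 4 `CC(C)(C)OC(=O)NCCCCCCNC(=O)COC1=CC(=O)c2c(O)cccc2C1=O` is the next entry: hydrogen in place of (tert-butoxycarbonyl)amino on a saturated chain carbon bound to two saturated chain carbons. Among the measured compounds shown here, no step between measured compounds covers this change, so nothing measured speaks to it directly. The two numbers available sit close together despite different chain ends, so the expected change is a 1.4-fold lower number from compound 3 to compound 4 (0.15 log units; within the scatter), small, if anything toward stronger inhibition, and not clearly beyond the scatter. In this assay compound 4 is estimated at 1000 nM, within 400 nM to 2500 nM.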

Compound 4, half-maximal inhibitory concentration: 300 nM
Compound 4: the middle estimate sits 3.3-fold (0.52 log units) above what was measured, outside the stated range (below it).
By their numbers in this assay, from the lowest: compound 4; then compounds 1 and 3 (each within the scatter of the next).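

In this assay, among the compounds shown here, the first step at this position gives a 4.7-fold lower number from compound 3 to compound 4 (0.67 log units; beyond the scatter), a change beyond the scatter, when hydrogen replaces (tert-butoxycarbonyl)amino on a saturated chain carbon bound to two saturated chain carbons. The earlier compounds shown here gave no reading at this position, and this step shows that the number here responds to the group on that carbon and that inhibition does not depend on the (tert-butoxycarbonyl)amino group there. No measured evidence bears on the reason for the step.

From the compounds shown here alone, whether the step follows from the loss of the whole group or of only its tert-butoxycarbonyl part stays open, and an amine or a methyl group on the same carbon would separate the two. Going by these compounds, whether a shorter or longer chain would shift the number of compound 4 also stays open.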